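The source may report more compounds than this note shows. Statements on the series, on what has been measured and on what is new or still open speak of the compounds shown alone.

Measured so far:
Compound 1 `CC(C)=CCC[C@@](C)(/C=C/c1ccccc1)/C=C/c1ccc(O)cc1`: > 26000 nM
Compound 2 `CC(C)=CCC[C@](C)(/C=C/c1ccc(O)cc1)/C=C/c1ccc(C#N)cc1`: > 26000 nM

Both results come from a functional assay on Raji cells (Homo sapiens) for cytotoxicity, with a stated time of 72 h; a lower number here means that less compound is needed, a higher number that more compound is needed for the effect. Compound 1 gives > 26000 nM, which is a limit of the assay and not a number. As far as these compounds go, compound 2 gives > 26000 nM, which is also a limit, so its true position remains unknown. Among the compounds with values here, the whole series so far stands at the limit of > 26000 nM in this assay, at which 2 of the 2 values shown sit.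

The next compound is compound 3 `CC(C)=CCC[C@](C)(/C=C/c1ccc(O)cc1)/C=C/c1cccc(Cl)c1`, with 3-chlorophenyl in place of 4-cyanophenyl on a double-bonded chain carbon bound to a double-bonded chain carbon.

Within the data shown here, the only measured step bearing on this is a step that the two limits leave unreadable from compound 1 to compound 2, and it offers no size to carry forward. No step beyond the usual scatter is therefore expected in this assay, and neither direction is favoured. The estimated step is a number no higher from compound 2 to compound 3 (the limit leaves the size open). Compound 3 is expected at 26000 nM, with an estimated range of 13000 nM to 52000 nM.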

Compound 3, half-maximal effective concentration: > 26000 nM
Compound 3 was reported as a limit; the forecaster's own chance of this, stated with the estimate: 70%; the middle value sits exactly at the limit.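

No step can be read among compound 1, compound 2 and compound 3, since each result is a limit and not a number: the limit of > 26000 nM in this assay, at which 3 of the 3 values shown sit.

The compounds shown leave open what concentration of any of them would give the effect in this assay, and whether exchanging these groups changes it.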